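Iodo for Trifluoromethyl: an Untested Step

The source may hold more compounds than are shown below. What is called first, only, known or untested is meant among the compounds shown, and "the series" means these compounds.

Compound 1, `CN1CCC/C1=N\C(=O)Nc1cccc(C(F)(F)F)c1`: > 25 mg/kg
Compound 2, `CN1CCC/C1=N\C(=O)Nc1c(Cl)cccc1Cl`: > 25 mg/kg

In a functional assay on the whole organism with Rattus norvegicus as the target, with a stated time of 5 days (a lower number here means that less compound is needed, a higher number that more compound is needed for the effect), compound 1 gives > 25 mg/kg, which is a limit of the assay and not a number. Compound 2 likewise gives only a limit, > 25 mg/kg. Compound 1 thus stands at the limit of > 25 mg/kg in this assay, at which 2 of the 2 values shown sit. Compound 3, `CN1CCC/C1=N\C(=O)Nc1cccc(I)c1`, differs from compound 1 by iodo in place of trifluoromethyl on an aromatic carbon. Among the measured compounds shown here, no step between measured compounds is known, so the data give no size for a change in this assay. The expected step from compound 1 to compound 3 is a number no higher from compound 1 to compound 3 (the limit leaves the size open), most likely none beyond the scatter. Compound 3 is expected to give about 25 mg/kg, between 8 mg/kg and 50 mg/kg.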

Compound 3, minimum effective dose: > 25 mg/kg
Compound 3 gave a limit, no number (the forecaster's own chance of this, stated with the estimate: 70%); the middle value lies on the limit itself.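

Among the compounds shown here, no step from compound 1 to compound 3 can be read, since both values are limits of the assay, not numbers: the limit of > 25 mg/kg in this assay, at which 3 of the 3 values shown sit. The compounds shown leave open what dose, if any, gives the effect in this assay, and whether iodo and trifluoromethyl differ there.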